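Fluoro in place of hydrogen on compound 2

A few compounds are considered here, and "the series" means these few. Any claim that something is new, unique, unknown or untested is made for them only; others in the source may bear on it.

Values measured in an ADME assay on a cell-free system (plasma, Rattus norvegicus) for protein binding (a lower number here means a smaller unbound share, a higher number a larger unbound share of the compound), are as follows
- compound 1 `COc1c(F)cccc1C1CCN(c2ccn3c(CC(F)(F)F)nnc3c2C#N)CC1` gives 0.04
- compound 2 `COc1ccc(F)cc1C1CCN(c2ccn3c(CC4CC4)nnc3c2Cl)CC1` gives < 0.01 (a limit)

Compound 2 stands at the limit of < 0.01 in this assay, at which 1 of the 2 values shown sits, and so has a limit, not a number. Compound 3 `COc1ccc(F)c(F)c1C1CCN(c2ccn3c(CC4CC4)nnc3c2Cl)CC1` carries fluoro in place of hydrogen on an aromatic carbon, turning 5-fluoro-2-methoxyphenyl into 2,3-difluoro-6-methoxyphenyl. Within the data shown here, no measured step sizes this change in this assay. The expected result is a step that the limit leaves unreadable from compound 2 to compound 3 (no shift beyond the scatter in either direction). For compound 3 the estimate is 0.007 (expected range 0.003 to 0.015), and a reading at the limit is likely.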

Compound 3, unbound fraction: < 0.01
Compound 3: a limit, no number (the forecaster's own chance of this, stated with the estimate: 65%); the middle value lies beyond the limit too.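

No step can be read from compound 2 to compound 3 in this assay, as both compounds sit at a limit: the limit of < 0.01 in this assay, at which 2 of the 3 values shown sit.

The compounds shown leave open whether the added fluoro changes the unbound fraction at all, and by how much.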